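This account rests on a few compounds, and the source may have more. Where it says the series, first, only, none or still open, it means among the compounds named here.

Compound 1, `CCN(CC)CN1C(=O)/C(=N/NC(=S)Nc2ccccc2)c2cc(Cl)ccc21`, in an ADME assay on MDCK cells (Canis lupus familiaris) for cytotoxicity (on this read-out higher numbers stand for lower toxicity in this test and lower numbers for higher toxicity in this test), gives >= 800 nM, a limit of the assay.
Compound 2, `CCN(CC)CN1C(=O)/C(=N/NC(N)=S)c2cc(Cl)ccc21`, in this assay gives 100000 nM.
Compound 3, `CCN(CC)CN1C(=O)/C(=N/NC(=S)Nc2ccc(OC)cc2)c2cc(Cl)ccc21`, in this assay gives >= 800 nM, a limit of the assay.

Compound 3 stands at the limit of this assay, and compound 1 sits at the same limit, which is the point of the limit of >= 800 nM in this assay, at which 2 of the 3 values shown sit. Compound 2 alone gives a number. Going by the values given here, none of the measured steps can be read: a step that the limit leaves unreadable from compound 1 to compound 2, a step that the two limits leave unreadable from compound 1 to compound 3 and a step that the limit leaves unreadable from compound 2 to compound 3 all stay hidden behind the limit. Compound 4, `CCN(CC)CN1C(=O)/C(=N/NC(=S)Nc2ccc(Cl)cc2)c2cc(Cl)ccc21`, differs from compound 3 by chloro in place of methoxy on an aromatic carbon. The nearest measured step, from compound 1 to compound 3, concerns the same aromatic carbon but gives no readable size, so no direction can be drawn from it. With two of three values at the limit, compound 4 is expected to sit there as well, so the step of a number no higher from compound 3 to compound 4 (the limit leaves the size open) is estimated to be none beyond the scatter. Compound 4 is therefore estimated at 800 nM, within 400 nM to 10000 nM.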

Compound 4, minimum cytotoxic concentration: >= 800 nM
Compound 4 gave a limit, no number (the forecaster's own chance of this, stated with the estimate: 70%); the middle value lies on the limit itself.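

No new step can be read: in this assay compound 4 gives a limit and not a number, so its steps involving compound 1, compound 2 and compound 3 stay hidden: the limit of >= 800 nM in this assay, at which 3 of the 4 values shown sit.

The compounds shown leave open how compound 1, compound 3 and compound 4 truly rank against one another and how far each lies from compound 2 in this assay.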